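Adding a Second Fluorine to the Phenyl Ring

A few compounds are considered here, and "the series" means these few. Any claim that something is new, unique, unknown or untested is made for them only; others in the source may bear on it.

Among the two compounds measured in a functional assay on HT-29 cells (Homo sapiens) for cytotoxicity, read by MTT assay, with a stated time of 72 h (on this read-out higher numbers stand for weaker inhibition and lower numbers for stronger inhibition), compound 2 `Cc1c(C(=O)Nc2ccc(Oc3ccnc4[nH]ccc34)c(F)c2)nnn1-c1ccccc1F` stands at 180 nM, within the scatter of compound 1 `Cc1c(C(=O)Nc2ccc(Oc3ccnc4[nH]ccc34)c(F)c2)nnn1-c1ccccc1` at 290 nM. The step of a 1.6-fold lower number from compound 1 to compound 2 (0.21 log units; within the scatter) involved a fluoro in place of hydrogen on an aromatic carbon. Compound 3 `Cc1c(C(=O)Nc2ccc(Oc3ccnc4[nH]ccc34)c(F)c2)nnn1-c1ccc(F)c(F)c1` differs by 3,4-difluorophenyl in place of 2-fluorophenyl on an aromatic nitrogen. That one measured step, a single added fluorine, stayed within the scatter, so no step beyond the scatter is expected here. The estimate for compound 3 is 180 nM, ranging from 90 nM to 360 nM. This expected step is no change at the digits printed from compound 2 to compound 3 (within the scatter).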

Compound 3, half-maximal inhibitory concentration: 610 nM
For compound 3 the middle estimate is 3.4-fold (0.53 log units) below the measured one, outside the stated range (above it).
By their numbers in this assay, from the lowest: compounds 2 and 1 (each within the scatter of the next); then compound 3.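

On the aromatic nitrogen, the group is not indifferent to fluorine: in this assay 3,4-difluorophenyl gives a 3.4-fold higher number from compound 2 to compound 3 (0.53 log units; beyond the scatter) against 2-fluorophenyl and a 2.1-fold higher number from compound 1 to compound 3 (0.32 log units; beyond the scatter) against plain phenyl, both weaker inhibition beyond the scatter. So adding fluorine to this ring does not in itself keep the number level, since the first added fluorine stayed within the scatter and this pair did not. Nothing at hand explains the difference. Which of the two fluorines matters stays open, as does how a phenyl carrying an amine or a carboxylic acid would behave here.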